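Series notes: from compound 3 to compound 4

A few compounds are considered here, and "the series" means these few. Any claim that something is new, unique, unknown or untested is made for them only; others in the source may bear on it.

Measured so far in a physicochemical assay for acid dissociation:
compound 1, `COc1ccc(F)cc1CNCCCNc1ccnc2cc(Cc3cc(C)cc(C)c3)ccc12`: 9.47
compound 2, `COc1ccc(F)cc1CNCCCNc1ccnc2cc(-c3cccc4ccccc34)ccc12`: 9.47
compound 3, `COc1cccc(CNCCCNc2ccnc3cc(CC4CCCCC4)ccc23)c1O`: 9.47

All three compounds share one core and differ only in the group on the aromatic carbon or on the saturated chain carbon bound to the amine nitrogen. Going by the values given here, the one computed step, no change at the digits printed from compound 1 to compound 2 (within the scatter), brought nothing beyond the scatter. Compound 3 stands level with compounds 1 and 2 at the digits shown; its nearest neighbour is compound 1 and its furthest is compound 2, and both gaps lie within the scatter.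

Compound 4, `COc1ccc(F)cc1CNCCCNc1ccnc2cc(CC3CCCCC3)ccc12`, differs from compound 3 by 5-fluoro-2-methoxyphenyl in place of 2-hydroxy-3-methoxyphenyl on a saturated chain carbon bound to an amine nitrogen. Among the compounds with values here, no measured step touches this part of the structure; the only measured step concerns the other variable position and left this assay unchanged.

Compound 4 is therefore expected to show no step beyond the scatter, an estimated step of no change at the digits printed from compound 3 to compound 4 (within the scatter). The estimate for compound 4 in this assay is 9.47, with a range from 9.1 to 9.8.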

Compound 4, acid dissociation constant: 9.47
Compound 4: the middle estimate sits on the measured number at the digits printed; low and high end bracket the measured number.
By their numbers in this assay, from the lowest: compounds 1, 2, 3 and 4 (each within the scatter of the next).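

In this assay the place on a saturated chain carbon bound to an amine nitrogen now has a step of its own: 5-fluoro-2-methoxyphenyl in place of 2-hydroxy-3-methoxyphenyl gives no change at the digits printed from compound 3 to compound 4 (within the scatter) even though the hydrogen-bond donor of the leaving group is absent from the entering one. At the other variable place, cyclohexylmethyl in place of naphthalen-1-yl on an aromatic carbon gives no change at the digits printed from compound 2 to compound 4 (within the scatter) and cyclohexyl in place of 3,5-dimethylphenyl on a saturated chain carbon bound to an aromatic carbon gives no change at the digits printed from compound 1 to compound 4 (within the scatter) as well, so saturated and aromatic rings read alike there in these compounds.

From the compounds shown here alone, whether a carboxylic acid or a dimethylamino group on the aromatic ring of the 5-fluoro-2-methoxybenzyl group would give a step beyond the scatter stays open. No supporting measurement bears on why the number holds across these changes.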